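A few compounds are considered here, and "the series" means these few. Any claim that something is new, unique, unknown or untested is made for them only; others in the source may bear on it.

Working notes on the series. Compound 1 `CC(c1ccc(-c2ccccc2)c(F)c1)c1nnc2n1N=C(c1ccc(Cl)cc1Cl)CS2` has been run in a functional assay on SNU-475 cells (Homo sapiens) for inhibition, read by sulforhodamine B assay, with a stated time of 72 h; a higher number here means a weaker inhibitor, a lower number a stronger inhibitor; in that setting compound 1 gives 4700 nM. Compound 2 `CC(C)Cc1ccc(C(C)c2nnc3n2N=C(c2ccc(Br)cc2)CS3)cc1` differs from compound 1 in more than one place; in this assay compound 2 gives 10100 nM. On these two numbers compound 1 stands lowest, with compound 2 the nearest and separated from it by a gap beyond the scatter. Among the measured compounds shown here, no pair differing in a single place has been measured, so the two values are all that the series shows so far.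

Compound 3 `CC(c1ccc(-c2ccccc2)c(F)c1)c1nnc2n1N=C(c1ccc(F)cc1)CS2` is not yet measured. It departs from compound 1 by one change: 4-fluorophenyl in place of 2,4-dichlorophenyl on a carbon with a double bond to nitrogen. For the measured compounds named here, no measured pair isolates this change, so its size rests on no direct comparison. The only other aryl variation at this carbon, in compound 2, comes bundled with a second change and a higher number, which is at best a weak pointer. The expectation for compound 3 is therefore a modest upward step, near the edge of the scatter, as a 1.6-fold higher number from compound 1 to compound 3 (0.20 log units; within the scatter). Compound 3 is estimated at 7500 nM, with a range from 3000 nM to 19000 nM.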

Compound 3, half-maximal inhibitory concentration: 6600 nM
Estimate against measurement, compound 3: 1.1-fold (0.06 log units) above; measured number inside the range.
By their numbers in this assay, from the lowest: compounds 1, 3 and 2 (each within the scatter of the next, the first and the last beyond it).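

The single-place comparison at the carbon with a double bond to nitrogen comes from compound 1 and compound 3. In this assay, 4-fluorophenyl in place of 2,4-dichlorophenyl gives a 1.4-fold higher number from compound 1 to compound 3 (0.15 log units; within the scatter) and so the two compounds cannot be told apart on this read-out. Among the compounds shown here, at this position, then, the two chlorine atoms of compound 1 can give way to the single fluorine of compound 3 with no difference that exceeds the scatter, which the bundled changes in compound 2 could not show. No measurement among these compounds offers an explanation for the two aryl groups reading alike.

Every aryl group shown at this carbon carries halogen, so it remains open how this position responds to a phenyl ring bearing an amine or a carboxylic acid, or to a non-aromatic group such as morpholine. Also open, on these data alone, is whether a single chlorine, as in 4-chlorophenyl, reads like the two groups compared here, and whether the same tolerance holds when the rest of the molecule differs from the core of compound 1.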